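From carboxylic acid to primary amide

The source may report more compounds than this note shows. Statements on the series, on what has been measured and on what is new or still open speak of the compounds shown alone.

Compound 3 `C[C@H](NC(=O)c1cc(F)cc2cc(-c3ccc(Cl)cc3)oc12)C(=O)O` gives 4440 nM in an assay on isolated protein for inhibition of endoplasmic reticulum aminopeptidase 1 (Homo sapiens), with stated times of 15 min and 20 min (a lower number here means a stronger inhibitor, a higher number a weaker inhibitor), the highest of the two measured numbers, with compound 2 `CN(C(=O)c1cc(F)cc2cc(-c3ccc(Cl)cc3)oc12)C(C)(C)C(=O)O` nearest at 1970 nM, as a 2.3-fold higher number from compound 2 to compound 3 (0.35 log units; beyond the scatter) shows. Compound 1 `COC(=O)C(C)(C)NC(=O)c1cc(F)cc2cc(-c3ccc(Cl)cc3)oc12` reached only the limit of the assay, > 10000 nM. Compound 4 `CC(C)(NC(=O)c1cc(F)cc2cc(-c3ccc(Cl)cc3)oc12)C(N)=O` differs from compound 3 in one place: 1-carbamoyl-1-methylethyl in place of 1-carboxyethyl on an amide-type nitrogen. Among the measured compounds shown here, the steps that bear on this both involve the free acid: an at least 2.2-fold lower number from compound 1 to compound 3 (0.35 log units; beyond the scatter), where an ester became an acid, and an at least 5.0-fold lower number from compound 1 to compound 2 (0.70 log units; beyond the scatter). In each the acid gives the lower number, so replacing it with a carbamoyl group is expected to raise the number, possibly back to the limit of > 10000 nM in this assay, at which 1 of the 3 values shown sits. Compound 4 is therefore estimated at 15000 nM, between 4000 nM and 50000 nM, which would mean a 3.4-fold higher number from compound 3 to compound 4 (0.53 log units; beyond the scatter).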

Compound 4, half-maximal inhibitory concentration: > 10000 nM
Compound 4: only a limit was reported; the forecaster's own chance of this, stated with the estimate: 60%; the middle value does not contradict the limit.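

In this assay, the primary amide falls behind both free acids, with an at least 2.2-fold higher number from compound 3 to compound 4 (0.35 log units; beyond the scatter) and an at least 5.0-fold higher number from compound 2 to compound 4 (0.70 log units; beyond the scatter). Compound 4 gives only a limit, as compound 1 does: the limit of > 10000 nM in this assay, at which 2 of the 4 values shown sit. Among these four compounds, only the two carboxylic acids give a readable number, while the step between the methyl ester and the primary amide cannot be read.

Both readable steps also change a methyl group, leaving the swap of acid for carbamoyl not cleanly separated from that change. On these data alone, whether a tetrazole in place of the carboxylic acid would give a readable number remains open.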